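Phenethyl for propyl on the aromatic oxygen of a melatonin ligand

The compounds below may be only part of what the source reports. "The series", "measured", "known", "first", "only" and "open" are said of these compounds alone.

Of the compounds shown here, three sharing one core have been measured in an assay on CHO cells for displacement of a labelled ligand from melatonin receptor type 1A (Homo sapiens), read by scintillation counting, with a stated time of 60 min; on this read-out higher numbers stand for weaker inhibition and lower numbers for stronger inhibition. Compound 1 `COc1ccc(O)c(CCCNC(C)=O)c1` gives 379 nM, compound 2 `CCOc1ccc(OC)cc1CCCNC(C)=O` gives 183 nM, and compound 3 `CCCOc1ccc(OC)cc1CCCNC(C)=O` gives 400 nM. Compound 3 thus carries the highest of the three numbers, its gap to compound 1 lying within the scatter. The new compound 4 `COc1ccc(OCCc2ccccc2)c(CCCNC(C)=O)c1` differs from compound 3 by phenyl in place of methyl on a saturated chain carbon, two bonds along the chain from an oxygen on an aromatic ring. Within the data shown here, the steps that bear on this change are a 2.2-fold higher number from compound 2 to compound 3 (0.34 log units; beyond the scatter) and a 1.1-fold higher number from compound 1 to compound 3 (0.02 log units; within the scatter): lengthening the chain at this place has so far given no lower number. Among the measured compounds shown here, no measured compound carries an aromatic ring here, so the expected 1.4-fold higher number from compound 3 to compound 4 (0.14 log units; within the scatter) is at most modest, leaning toward a higher number. Compound 4 is therefore estimated at 550 nM, within 150 nM to 2000 nM.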

Compound 4, inhibition constant: 2930 nM
Beside the measured number, compound 4's estimate is 5.3-fold (0.73 log units) below it; the whole stated range lies below it.
By their numbers in this assay, from the lowest: compound 2; then compounds 1 and 3 (each within the scatter of the next); then compound 4.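

In this assay, among these compounds, the phenyl at the end of the chain on this oxygen weakens binding more than chain lengthening had so far, with phenyl in place of methyl giving a 7.3-fold higher number from compound 3 to compound 4 (0.86 log units; beyond the scatter). The step from the ethyl compound is the largest here, a 16-fold higher number from compound 2 to compound 4 (1.20 log units; beyond the scatter), and the step from the compound with hydrogen on this oxygen is a 7.7-fold higher number from compound 1 to compound 4 (0.89 log units; beyond the scatter). This position therefore allows a large rise in the number, which the three smaller groups had not shown.

Nothing available explains this rise. From the compounds shown here alone, whether the aromatic ring or the added length matters more stays open, and butyl or cyclohexylethyl on this oxygen would help separate the two.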